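Taking the chloro group off compound 2

This account rests on a few compounds, and the source may have more. Where it says the series, first, only, none or still open, it means among the compounds named here.

Compound 1 (`C=C1C(=O)OC[C@@H]1CCOC(=O)Nc1cc(C)cc(C)c1`): 1240 nM
Compound 2 (`C=C1C(=O)OC[C@H]1CCOC(=O)Nc1ccc(Cl)cc1`): 390 nM

In a functional assay on RAW264.7 cells (Mus musculus) for inhibition, with a stated time of 30 min (on this read-out higher numbers stand for weaker inhibition and lower numbers for stronger inhibition), compound 2 holds the lower of the two numbers at 390 nM and so shows the stronger inhibition. Compound 1 gives 1240 nM by comparison, a gap beyond the usual scatter of such measurements. These two compounds differ in more than one place, so their gap cannot be tied to any single feature.

Compound 3 (`C=C1C(=O)OC[C@H]1CCOC(=O)Nc1ccccc1`) is compound 2 with hydrogen in place of chloro on an aromatic carbon. Within the data shown here, no measured pair shows this change on its own, so any forecast is uncertain. The only hint is weak: compound 1 also has no chloro group and gives 1240 nM in this assay as the higher number. A modest move towards weaker inhibition is therefore expected, an estimated 1.9-fold higher number from compound 2 to compound 3 (0.28 log units; within the scatter) that may not reach far past the scatter. In this assay the estimate for compound 3 is 750 nM within an expected range of 300 nM to 1800 nM as a working figure.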

Compound 3, half-maximal inhibitory concentration: 390 nM
Estimate against measurement, compound 3: 1.9-fold (0.28 log units) above; the range from low to high includes it.
By their numbers in this assay, from the lowest: compounds 2 and 3 (each within the scatter of the next); then compound 1.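

In this assay, putting hydrogen in place of chloro on an aromatic carbon gives no change at the digits printed from compound 2 to compound 3 (within the scatter). Among these compounds, this is the first comparison that changes a single place, and it shows that the chloro group, para to a large group, is not required for the inhibition measured here: with or without it, the two compounds cannot be told apart. The earlier pair could not show this, since those two compounds differ in more than one place, and nothing available here explains why this swap leaves the number where it stands.

On these data alone, a single swap compares only chloro with hydrogen, so it remains open whether a larger or quite different group at this place, such as an amine, a methoxy group or a carboxylic acid, would also leave the number in the same range. As far as these compounds go, it also remains open whether removing the chloro group would read the same way on a compound that differs elsewhere, for instance in the chain or in the shared core.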